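The source may report more compounds than this note shows. Statements on the series, on what has been measured and on what is new or still open speak of the compounds shown alone.

Compound 1 `Cc1ccccc1CN1CCc2c(sc(NC(=O)c3ccccc3Cl)c2C(N)=O)C1`: in a functional assay on MKN-74 cells (Homo sapiens) for antiproliferative activity, with a stated time of 24 h (a higher number here means a weaker inhibitor, a lower number a stronger inhibitor), compound 1 gives > 50000 nM, which is a limit of the assay and not a number.
Compound 2 `N#Cc1ccccc1CN1CCc2c(sc(NC(=O)c3ccccc3Cl)c2C(N)=O)C1`: compound 2 gives 9500 nM.
Compound 3 `NC(=O)c1c(NC(=O)c2ccccc2Cl)sc2c1CCN(C(=S)Nc1ccccc1F)C2`: compound 3 gives 12600 nM.

Among the two numbers shown, compound 3 holds the higher one, yet its gap to compound 2 is small: a 1.3-fold higher number from compound 2 to compound 3 (0.12 log units; within the scatter). Compound 1 is only known to sit at a limit, (the limit of > 50000 nM in this assay, at which 1 of the 3 values shown sits).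

Compound 4 `NC(=O)c1c(NC(=O)c2ccccc2Cl)sc2c1CCN(C(=S)Nc1ccccc1-c1ccccc1)C2` differs from compound 3 in a single place: phenyl in place of fluoro on an aromatic carbon. The measured steps all concern the group on the amine nitrogen in a ring, where an at least 5.2-fold lower number from compound 1 to compound 2 (0.72 log units; beyond the scatter) and an at least 3.9-fold lower number from compound 1 to compound 3 (0.59 log units; beyond the scatter) both start from the limit of compound 1, while a 1.3-fold higher number from compound 2 to compound 3 (0.12 log units; within the scatter) stays within the scatter. Among the measured compounds shown here, none of these steps touches the ring that carries the fluoro, so no measured step bears directly on the change made in compound 4. As far as these compounds go, what remains is that a swap of aryl-ring substituents has not been tested here at all, so the direction of the change is unknown, and the expected step is a 1.1-fold lower number from compound 3 to compound 4 (0.02 log units; within the scatter), carrying wide uncertainty. Compound 4 is therefore estimated to give about 12000 nM, with a range from 3000 nM to 50000 nM.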

Compound 4, half-maximal inhibitory concentration: 25800 nM
Beside the measured number, compound 4's estimate is 2.2-fold (0.33 log units) below it, and the stated range covers the measured number.
By their numbers in this assay, from the lowest: compounds 2 and 3 (each within the scatter of the next); then compound 4. At a limit, above all of these: compound 1.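

Among the compounds shown here, this is the first step that changes the ring carrying the fluoro rather than the whole group on the ring nitrogen, and it shows that this place, ortho to a large group, does respond to what sits on it: in this assay there is a 2.0-fold higher number from compound 3 to compound 4 (0.31 log units; beyond the scatter), a modest weakening that lies just beyond the scatter. The step is also small for so large a change in size, since phenyl, with its aromatic ring, replaces fluoro, and compound 4 still gives a measured number rather than reaching a limit of the assay. The data at hand offer no explanation for why phenyl gives the higher number here.

As far as these compounds go, a single step cannot set a trend with group size, so it remains open what a methyl, a methoxy or an amine at this same place would give, and whether plain hydrogen would read closer to compound 3 or to compound 4. From the compounds shown here alone, it is equally open whether phenyl placed elsewhere on this ring would give a similar number.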